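Swapping a Vinyl for an Ethoxy on the Imidazole Core

The source may hold more compounds than are shown below. What is called first, only, known or untested is meant among the compounds shown, and "the series" means these compounds.

Within the data shown here, compound 2, whose structure is `C=Cc1nc(CC)n2c1C(CCc1ccc(C(F)(F)F)cc1)N([C@@H](C(=O)NC)c1ccccc1)CC2`, is the stronger of the two compounds measured so far: in a functional assay on CHO cells for antagonist activity at Orexin/Hypocretin receptor type 1 (Homo sapiens), read by FLIPR and calcium flux (a lower number here means a stronger inhibitor, a higher number a weaker inhibitor), compound 2 gives 150 nM. Among the measured compounds shown here, its only neighbour is compound 1, with structure `CCc1nc(C(C)C)c2n1CCN([C@@H](C(=O)NC)c1ccccc1)C2CCc1ccc(C(F)(F)F)cc1`, which in this assay gives 10000 nM. For the measured compounds named here, the one measured step, a 67-fold lower number from compound 1 to compound 2 (1.82 log units; beyond the scatter), shows that a change of the group at this position on the aromatic carbon can move the number a long way.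

Compound 3, with structure `CCOc1nc(CC)n2c1C(CCc1ccc(C(F)(F)F)cc1)N([C@@H](C(=O)NC)c1ccccc1)CC2`, differs from compound 2 by a change at the same position: ethoxy in place of vinyl on an aromatic carbon. Going by the values given here, only the step from compound 1 to compound 2 bears on this, and it concerns a different pair of groups, so it says that the position is sensitive without saying in which direction an ethoxy will push. Because compound 2 already gives 150 nM, there is more room for the number to rise than to fall, and the expected step in this assay for compound 3 is a 3.3-fold higher number from compound 2 to compound 3 (0.52 log units; beyond the scatter). Compound 3 is therefore estimated at 500 nM, with a likely range from 100 nM to 3000 nM.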

Compound 3, half-maximal inhibitory concentration: 3980 nM
Compound 3: middle estimate off by 8.0-fold (0.90 log units), on the low side, and the stated range ends below it.
By their numbers in this assay, from the lowest: compound 2; then compound 3; then compound 1.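

In this assay, the change from vinyl to ethoxy gives a 27-fold higher number from compound 2 to compound 3 (1.42 log units; beyond the scatter), which shows that this position can punish a change as sharply as it rewarded the earlier one, and that an ethoxy does not keep the strength seen with vinyl. Ethoxy in place of isopropyl gives only a 2.5-fold lower number from compound 1 to compound 3 (0.40 log units; beyond the scatter), a modest step though beyond the scatter, so among these three groups vinyl stands well apart from the other two, while ethoxy and isopropyl lie much closer together. Nothing available here explains why vinyl stands apart, and the counts do not settle it, as vinyl brings a double bond outside the aromatic rings and ethoxy brings an oxygen and a hydrogen-bond acceptor.

Among these compounds, with only three groups compared at this position, it remains open whether the strength of compound 2 depends on the double bond or simply on the absence of the oxygen and of the branching. An ethynyl group, a methoxy group or a cyclopropyl ring at the same place would help to separate these possibilities.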